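The compounds below may be only part of what the source reports. "The series", "measured", "known", "first", "only" and "open" are said of these compounds alone.

Working notes on the sulfonamide series. Compound 1 `O=S(=O)(c1ccc(C(F)(F)F)cc1)N(CCCN1CCN(c2ccccc2)CC1)CC1CCCCC1` gives 456 nM in an assay on CHO cells for displacement of a labelled ligand from 5-hydroxytryptamine receptor 7 (Homo sapiens); on this read-out higher numbers stand for weaker inhibition and lower numbers for stronger inhibition. Compound 2 `COc1ccc(S(=O)(=O)N(CCCN2CCN(c3cccc(C(F)(F)F)c3)CC2)CC2CCCCC2)cc1` gives 678 nM in this assay; of the two numbers compound 1 holds the smaller, and the gap to compound 2 lies within the scatter, so the pair shows no difference. Compound 3 `O=S(=O)(c1ccc2ccccc2c1)N(CCCN1CCN(c2ccccc2)CC1)CC1CCCCC1` carries naphthalen-2-yl in place of 4-(trifluoromethyl)phenyl on a sulfonyl sulfur on the core of compound 1. Going by the values given here, no measured pair covers this exchange, so the step of a 1.5-fold lower number from compound 1 to compound 3 (0.18 log units; within the scatter) from compound 1 to compound 3 is an estimate only, expected to be small and toward a lower number. Compound 3 is expected at 300 nM in this assay, with a range of 100 nM to 900 nM.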

Compound 3, half-maximal inhibitory concentration: 1240 nM
Estimate against measurement, compound 3: 4.1-fold (0.62 log units) below; measured number outside the range, above it.
By their numbers in this assay, from the lowest: compounds 1, 2 and 3 (each within the scatter of the next, the first and the last beyond it).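

Going by these compounds alone, on a sulfonyl sulfur of the core of compound 1, naphthalen-2-yl in place of 4-(trifluoromethyl)phenyl gives a 2.7-fold higher number from compound 1 to compound 3 (0.43 log units; beyond the scatter) in this assay, the first step beyond the scatter. Both groups count 10 heavy atoms, so this position responds to the exchange even at an equal count, though only modestly. Nothing on hand accounts for the step. As far as these compounds go, it remains open whether the second aromatic ring or the loss of trifluoromethyl carries the step. Also open, from the compounds shown here alone, is how a plain phenyl or a pyridine ring would read on this sulfur.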